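A few compounds are considered here, and "the series" means these few. Any claim that something is new, unique, unknown or untested is made for them only; others in the source may bear on it.

This piece follows the change from compound 1 to compound 4, asking how much compound reaches the bloodstream after dosing in rats. Compound 1 `CN1CCN(CCCS(=O)(=O)c2ccc3nc(NC(=O)NC(=O)c4cc(C5CC5)ccc4Cl)sc3c2)CC1` was measured in an ADME assay on the whole organism (strain Han-Wistar) for pharmacokinetics, with Rattus norvegicus as the target, read by LC-MS, at a dose of 2 mg/kg by the oral route (a higher number here means more compound in the circulation at the dose given, a lower number less compound in the circulation), and gave 1400 nM. Two other compounds share its core. Compound 3 `CCN(CC)CCCS(=O)(=O)c1ccc2nc(NC(=O)NC(=O)c3cc(-n4cccn4)ccc3Cl)sc2c1` gives 1600 nM in this assay, a number within the usual scatter of that for compound 1, so the two cannot be told apart. Compound 2 `CN1CCN(CCCS(=O)(=O)c2ccc3nc(NC(=O)NC(=O)c4cc(-n5cccn5)c(Cl)cc4Cl)sc3c2)CC1` gives 30 nM in this assay, far below compound 1 and well beyond the scatter. Among the three numbers compound 1 thus stands second highest, near compound 3 and distant from compound 2.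

Compound 4 `CN1CCN(CCCS(=O)(=O)c2ccc3nc(NC(=O)NC(=O)c4cccc(-n5cccn5)c4Cl)sc3c2)CC1` has not yet been measured. It differs from compound 1 in one place: 2-chloro-3-(1H-pyrazol-1-yl)phenyl in place of 2-chloro-5-cyclopropylphenyl on a carbonyl carbon. Within the data shown here, no pair of measured compounds differs by exactly this change, so there is no directly matching step to lean on. The three measured numbers show that the group on this carbonyl carbon can shift exposure strongly in either direction. A moderate fall is expected for compound 4, as a 2.8-fold lower number from compound 1 to compound 4 (0.45 log units; beyond the scatter), with wide uncertainty. Compound 4 is estimated at 500 nM in this assay, within a range from 60 nM to 3000 nM.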

Compound 4, maximal plasma concentration: 12 nM
Compound 4: the middle estimate sits 42-fold (1.62 log units) above what was measured, outside the stated range (below it).
By their numbers in this assay, from the lowest: compound 4; then compound 2; then compounds 1 and 3 (each within the scatter of the next).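

Read in this assay, the exchange at this carbonyl carbon gives a 120-fold lower number from compound 1 to compound 4 (2.07 log units; beyond the scatter), with the rest of compound 1 left as it was. Among these compounds, the earlier compounds showed a wide spread of numbers, but no pair of them differed in one place, so this is the first direct sign that this group alone can decide how much compound reaches the circulation. The change looks small on paper: both groups keep the chlorine and the six-membered aromatic ring of carbon only, yet the entering pyrazole ring brings 2 hydrogen-bond acceptors where the leaving group has 0.

The compounds shown cannot separate the effect of exchanging cyclopropyl for pyrazole from the effect of moving the ring from the 5 position in the group's name to the 3 position. A 2-chloro-3-cyclopropylphenyl or a 2-chloro-5-(1H-pyrazol-1-yl)phenyl group on the core of compound 1 would pull these two apart.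

Nothing measured here accounts for the size of this fall.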